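The source may report more compounds than this note shows. Statements on the series, on what has been measured and on what is new or still open speak of the compounds shown alone.

In an ADME assay on HepG2 2.2.15 cells (Homo sapiens) for cytotoxicity (a lower number here means that less compound is tolerated, a higher number that more compound is tolerated), compound 3 `O=C(O)CCCC(=O)OCCc1c(-c2ccccc2Cl)c2cc(Cl)ccc2[nH]c1=O` gives 110000 nM. Compound 2 `CCC(=O)OCCc1c(-c2ccccc2Cl)c2cc(Cl)ccc2[nH]c1=O` gives 95000 nM in this assay, and the two numbers lie within the scatter of each other, as the step of a 1.2-fold higher number from compound 2 to compound 3 (0.06 log units; within the scatter) shows. Compound 1 `O=c1c(CCO)c(-c2ccccc2Cl)c2cc(Cl)ccc2n1-c1c(F)cccc1F` gives in this assay only a limit, > 2300000 nM, and not a number. Among the values shown, compound 3 thus stands level with compound 2, and the only other entry is that limit.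

Compound 4 `O=C(OCCc1c(-c2ccccc2Cl)c2cc(Cl)ccc2[nH]c1=O)c1ccccc1` differs from compound 3 at a single place: phenyl in place of 3-carboxypropyl on a carbonyl carbon. Among the measured compounds shown here, only one measured step bears on this part of the molecule, the step from compound 2 to compound 3, which also changed the group carried by the carbonyl carbon and came out as a 1.2-fold higher number from compound 2 to compound 3 (0.06 log units; within the scatter). The two esters compound 2 and compound 3 therefore sit together in this assay, and nothing measured here points to a move beyond the scatter when phenyl replaces 3-carboxypropyl on that carbonyl carbon. Compound 4 is accordingly expected to give about 80000 nM in this assay, with a range from 30000 nM to 250000 nM. This estimate means an expected step of a 1.4-fold lower number from compound 3 to compound 4 (0.14 log units; within the scatter).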

Compound 4, half-maximal cytotoxic concentration: 43000 nM
Compound 4: middle estimate off by 1.9-fold (0.27 log units), on the high side, and the stated range covers the measured number.
By their numbers in this assay, from the lowest: compound 4; then compounds 2 and 3 (each within the scatter of the next). At a limit, above all of these: compound 1.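

In this assay, among the compounds shown here, the group on this carbonyl carbon turns out to matter: ethyl and 3-carboxypropyl had stood within the scatter of each other, but phenyl brings the first change here that goes beyond it, with a 2.6-fold lower number from compound 3 to compound 4 (0.41 log units; beyond the scatter) and a 2.2-fold lower number from compound 2 to compound 4 (0.34 log units; beyond the scatter). Less of the benzoyl ester compound 4 is therefore tolerated than of either chain ester, although both steps are modest, and the change is tied to phenyl rather than to the loss of the carboxylic acid end alone, as the step from ethyl, which has no such end, also lies beyond the scatter. Nothing measured here gives a reason for this shift.

The compounds shown leave open whether the lower number belongs to the aromatic ring as such or to any ring on this carbonyl carbon, which a cyclohexyl group would test, and whether it survives a longer chain between the carbonyl and the phenyl, as in a benzyl group. Also open, as far as these compounds go, is how an amine or a chlorine on the phenyl ring would shift the number, and where the same core with a free hydroxyl and no ester would stand.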